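The source may hold more compounds than are shown below. What is called first, only, known or untested is meant among the compounds shown, and "the series" means these compounds.

Measured in a functional assay on L1210 cells (Mus musculus) for inhibition; on this read-out lower numbers stand for stronger inhibition and higher numbers for weaker inhibition:
- Compound 1 `O=C1O/C(=C\Cn2cc(C(F)(F)F)c(=O)[nH]c2=O)C(OCc2ccccc2)=C1OCc1ccccc1`: 2000 nM
- Compound 2 `O=C1O/C(=C\Cn2cc(I)c(=O)[nH]c2=O)C(OCc2ccccc2)=C1OCc1ccccc1`: 7500 nM
- Compound 3 `O=C1O/C(=C\Cn2cnc3c(-n4cccc4)ncnc32)C(OCc2ccccc2)=C1OCc1ccccc1`: 110000 nM

Compound 2 holds the middle place among these three numbers, with compound 1 lower and compound 3 higher. The next compound, compound 4 `O=C1O/C(=C\Cn2cc(Br)c(=O)[nH]c2=O)C(OCc2ccccc2)=C1OCc1ccccc1`, departs from compound 2 in one place: bromo in place of iodo on an aromatic carbon. Going by the values given here, one measured step bears on this change: a 3.8-fold higher number from compound 1 to compound 2 (0.57 log units; beyond the scatter), where iodo took the place of trifluoromethyl on an aromatic carbon. That step was modest. Among the compounds with values here, compound 3 differs from compound 2 in more than one place and offers no comparable step. Within the data shown here, no measured compound carries bromo, so the evidence is thin. Going by the modest step to compound 2, a smaller change is expected here, leaning slightly towards a lower number and probably staying within the scatter. The expected step is a 1.5-fold lower number from compound 2 to compound 4 (0.18 log units; within the scatter). For compound 4 the estimated value is 5000 nM, with an expected range from 1800 nM to 14000 nM.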

Compound 4, half-maximal inhibitory concentration: 7500 nM
Compound 4: the middle estimate sits 1.5-fold (0.18 log units) below what was measured; low and high end bracket the measured number.
By their numbers in this assay, from the lowest: compound 1; then compounds 2 and 4 (each within the scatter of the next); then compound 3.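

In this assay, exchanging iodo for bromo on this aromatic carbon gives no change at the digits printed from compound 2 to compound 4 (within the scatter), so the two halogens cannot be told apart at this position of the six-membered aromatic ring with 2 nitrogen. Trifluoromethyl stands apart from both, since a 3.8-fold higher number from compound 1 to compound 4 (0.57 log units; beyond the scatter) matches the earlier step, a 3.8-fold higher number from compound 1 to compound 2 (0.57 log units; beyond the scatter), and the gap at this position thus appears with either halogen, not only with iodo. Nothing measured here accounts for this difference or for the equal numbers of the two halogens.

The compounds shown leave open whether a smaller group at this place, such as chloro, fluoro or methyl, would group with the two halogens or with trifluoromethyl. They also leave open how a nitrile or an amine on the same carbon would read in this assay.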